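The source may report more compounds than this note shows. Statements on the series, on what has been measured and on what is new or still open speak of the compounds shown alone.

Compound 2, `CCCCOC(=O)N1CCC(Oc2ncnc3c2CCN3c2ccc(S(C)(=O)=O)cc2F)CC1`, and compound 1, `COC(=O)N1CCC(Oc2ncnc3c2CCN3c2ccc(S(C)(=O)=O)cc2F)CC1`, share one core and differ only in the chain attached to the oxygen next to the carbonyl group. In a functional assay on CHO-K1 cells for agonist activity at Glucose-dependent insulinotropic receptor (Homo sapiens), read by a luciferase reporter, with a stated time of 5 h (a lower number here means that less compound is needed, a higher number that more compound is needed for the effect), compound 1 gives 316 nM, while compound 2 gives 50.1 nM. That single change, a 6.3-fold lower number from compound 1 to compound 2 (0.80 log units; beyond the scatter), leaves compound 2 with the lowest number of the two measured compounds.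

Compound 3, `COCCOC(=O)N1CCC(Oc2ncnc3c2CCN3c2ccc(S(C)(=O)=O)cc2F)CC1`, is reached from compound 2 by methoxy in place of ethyl on a saturated chain carbon, two bonds along the chain from an oxygen next to a carbonyl group. Going by the values given here, only the step from compound 1 to compound 2 bears on this, and it speaks to adding chain atoms rather than to swapping one two-atom group for another of the same size. That step was a modest one, and the present change keeps the chain length, so the expected move in this assay is small and uncertain in direction. Compound 3 is therefore estimated at 100 nM, within 40 nM to 250 nM, a step of a 2.0-fold higher number from compound 2 to compound 3 (0.30 log units; within the scatter) that is expected to stay near the scatter.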

Compound 3, half-maximal effective concentration: 316 nM
For compound 3 the middle estimate is 3.2-fold (0.50 log units) below the measured one; the whole stated range lies below it.
By their numbers in this assay, from the lowest: compound 2; then compounds 1 and 3 (each within the scatter of the next).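

In this assay, methoxy in place of ethyl, on a saturated chain carbon two bonds along the chain from an oxygen next to a carbonyl group, gives a 6.3-fold higher number from compound 2 to compound 3 (0.80 log units; beyond the scatter) even though both groups count 2 heavy atoms. The gain seen with the butyl chain of compound 2 is therefore not kept by every chain of that length, since the 2-methoxyethyl chain gives no change at the digits printed from compound 1 to compound 3 (within the scatter) and the longer chain brings no gain over the shared core's short one. No measurement at hand explains this difference.

The compounds shown leave open whether the result follows the oxygen itself or its place along the chain. Going by these compounds, how a longer chain such as hexyl, or a chain ending in an amine, would behave also remains open.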